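A few compounds are considered here, and "the series" means these few. Any claim that something is new, unique, unknown or untested is made for them only; others in the source may bear on it.

Compound 1 `CC(C)(C)C#Cc1cc(N(C(=O)[C@H]2CC[C@H](C)CC2)[C@H]2CC[C@H](Oc3ccccn3)CC2)c(C(=O)O)s1` gives 100 nM in an ADME assay on MT4 cells (Homo sapiens) for cytotoxicity, with a stated time of 5 days (a lower number here means that less compound is tolerated, a higher number that more compound is tolerated), the lowest of the three numbers recorded there. Compound 3 `CC(C)(C)C#Cc1cc(N(C(=O)[C@H]2CC[C@H](C)CC2)[C@H]2CC[C@H](OC3CCOCC3)CC2)c(C(=O)O)s1` gives 1990 nM and compound 2 `CC1=CC[C@H](C(=O)N(c2cc(C#CC(C)(C)C)sc2C(=O)O)[C@H]2CC[C@](O)(CO[C@H]3CCOC3)CC2)CC1` gives 12100 nM. Compound 4 `CC(C)(C)C#Cc1cc(N(C(=O)[C@H]2CC[C@H](C)CC2)[C@H]2CC[C@H](Oc3ccncn3)CC2)c(C(=O)O)s1` differs from compound 1 at a single place: pyrimidin-4-yl in place of pyridin-2-yl on an oxygen on a saturated carbon. Among the compounds with values here, only one measured step touches the same oxygen on a saturated carbon, a 20-fold higher number from compound 1 to compound 3 (1.30 log units; beyond the scatter), but there a saturated ring replaced the aromatic one, whereas compound 4 keeps a six-membered aromatic ring and adds a second hetero atom. Within the data shown here, compound 2 carries changes at several places and offers no single step to compare. A step smaller than that toward compound 3 is therefore expected, a 2.5-fold higher number from compound 1 to compound 4 (0.40 log units; beyond the scatter), most likely toward a higher number. Compound 4 is estimated at 250 nM, within a range of 80 nM to 1000 nM.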

Compound 4, half-maximal cytotoxic concentration: 599 nM
Beside the measured number, compound 4's estimate is 2.4-fold (0.38 log units) below it; the measured number falls inside the stated range.
By their numbers in this assay, from the lowest: compound 1; then compound 4; then compound 3; then compound 2.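

In this assay, the hetero atoms of the aromatic ring on this oxygen matter on their own: with the ring still six-membered and aromatic, pyrimidin-4-yl in place of pyridin-2-yl gives a 6.0-fold higher number from compound 1 to compound 4 (0.78 log units; beyond the scatter). The saturated oxan-4-yl still stands apart from pyrimidin-4-yl, with a 3.3-fold lower number from compound 3 to compound 4 (0.52 log units; beyond the scatter), so these three compounds form a graded series rather than a simple split between aromatic and saturated rings. No measurement shown accounts for either step. The compounds shown leave open where a phenyl ring on this oxygen would stand in this series. They also leave open how pyrazin-2-yl would compare with pyrimidin-4-yl.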